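Chloro to Methoxy on a Shared Core: an Expected Step

The source may hold more compounds than are shown below. What is called first, only, known or untested is meant among the compounds shown, and "the series" means these compounds.

Measured compounds:
- compound 1, `O=C(C=CNc1cc(-c2ccccc2)nn1-c1ccccc1)c1cccs1`: 15400 nM
- compound 2, `N#Cc1c(-c2ccc(Cl)cc2)nc2c(c(-c3ccccc3)nn2-c2ccccc2)c1-c1ccc(N2CCCCC2)cc1`: 10600 nM
- compound 3, `O=C(C=CNc1cc(-c2ccccc2)nn1-c1ccccc1)c1ccc(F)cc1`: 9180 nM

All three were tested in a functional assay on MCF7 cells (Homo sapiens) for inhibition, read by MTT assay, with a stated time of 48 h; on this read-out lower numbers stand for stronger inhibition and higher numbers for weaker inhibition. Compound 1 gives 15400 nM, compound 2 gives 10600 nM and compound 3 gives 9180 nM. Compound 2 sits among the other two: its gap to compound 3 and its gap to compound 1 each lie within the usual scatter of repeated measurements, so the three values cannot be told apart.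

Compound 4, `COc1ccc(-c2nc3c(c(-c4ccccc4)nn3-c3ccccc3)c(-c3ccc(N4CCCCC4)cc3)c2C#N)cc1`, has not yet been measured. It differs from compound 2 in one place: methoxy in place of chloro on an aromatic carbon.

Among the compounds with values here, the only measured step, a 1.7-fold lower number from compound 1 to compound 3 (0.22 log units; within the scatter), concerns a different core and a different kind of exchange, and it stayed within the scatter. Within the data shown here, there is no measured pair in which chloro gives way to methoxy, so the data give no direction for this change. The expectation is therefore that compound 4 lands close to compound 2, with a step of a 1.1-fold lower number from compound 2 to compound 4 (0.03 log units; within the scatter) that is not expected to exceed the scatter.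

Compound 4 is estimated to give 10000 nM in this assay, with a likely range from 4000 nM to 25000 nM.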

Compound 4, half-maximal inhibitory concentration: 2760 nM
For compound 4 the middle estimate is 3.6-fold (0.56 log units) above the measured one; the whole stated range lies above it.
By their numbers in this assay, from the lowest: compound 4; then compounds 3, 2 and 1 (each within the scatter of the next).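

In this assay, replacing 4-chlorophenyl with 4-methoxyphenyl on the shared core gives a 3.8-fold lower number from compound 2 to compound 4 (0.58 log units; beyond the scatter), a step beyond the scatter. This shows that the aromatic carbon para to a large group is a place where the choice of substituent can change the read-out, and that in this pair methoxy goes with the stronger inhibition. Within the data shown here, the earlier compounds could not show this, as their only measured step stayed within the scatter and involved a different core and a different exchange, and nothing available here explains the new step.

The compounds shown leave open how a hydroxyl group, an amino group or a longer chain such as ethoxy would compare at this same place, and so whether the step is particular to methoxy or would extend to other groups. They also leave open whether replacing chloro with methoxy would give a step of similar size if other groups on the shared core were changed.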